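This account rests on a few compounds, and the source may have more. Where it says the series, first, only, none or still open, it means among the compounds named here.

Measured so far in an assay on cell membranes for displacement of a labelled ligand from Neuronal acetylcholine receptor; alpha4/beta2 (Rattus norvegicus); on this read-out higher numbers stand for weaker inhibition and lower numbers for stronger inhibition:
compound 1, `O=[N+]([O-])c1ccc(Nc2ccc(N3CC4CC(C3)N4)cn2)cc1`, gives 1.76 nM.
compound 2, `Oc1ccc(Nc2ccc(N3CC4CC(C3)N4)cn2)cc1`, gives 7.1 nM.

Within the data shown here, compound 2 holds the highest number of the two; its only neighbour is compound 1, from which it is set apart by a 4.0-fold higher number from compound 1 to compound 2 (0.61 log units; beyond the scatter), a step that lies beyond the scatter.

Compound 3, `FC(F)(F)c1ccc(Nc2ccc(N3CC4CC(C3)N4)cn2)cc1`, awaits measurement in this assay. It differs from compound 2 as follows: trifluoromethyl in place of hydroxy on an aromatic carbon.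

Among the measured compounds shown here, the only measured step on this aromatic carbon is a 4.0-fold higher number from compound 1 to compound 2 (0.61 log units; beyond the scatter), which shows that exchanging the group at this place moves the number by a modest amount. For the measured compounds named here, no measured pair involves the trifluoromethyl group itself, so the direction of the step from compound 2 to compound 3 is not fixed by the data. Given that the group present in compound 1 gave the lower number, a lower number than compound 2 is tentatively expected, with the range kept wide.

Compound 3 is therefore estimated at 3.5 nM, between 1.2 nM and 12 nM. This expected outcome corresponds to a 2.0-fold lower number from compound 2 to compound 3 (0.31 log units; beyond the scatter).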

Compound 3, inhibition constant: 0.569 nM
Compound 3: middle estimate off by 6.2-fold (0.79 log units), on the high side; the measured number lies below the stated range.
By their numbers in this assay, from the lowest: compound 3; then compound 1; then compound 2.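

In this assay, among these compounds, the position tolerates wider change than the single earlier step suggested: a 12-fold lower number from compound 2 to compound 3 (1.10 log units; beyond the scatter) is large, whereas hydroxy to nitro was only modest. Nitro also no longer marks the low end at this aromatic carbon, since a 3.1-fold lower number from compound 1 to compound 3 (0.49 log units; beyond the scatter) is likewise beyond the scatter, and the lowest number of the three belongs to trifluoromethyl, which counts no hydrogen-bond donor or acceptor. Nothing at hand accounts for this order of the three groups.

Still open, as far as these compounds go, is where an amine, a methoxy group, a chlorine atom or a carboxylic acid on this carbon would fall relative to these three groups. Also open, from the compounds shown here alone, is whether trifluoromethyl would keep its low number on a different carbon of the same ring or with a change elsewhere in the shared core.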